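Fluoro on the core: from compound 2 to compound 4

A few compounds are considered here, and "the series" means these few. Any claim that something is new, unique, unknown or untested is made for them only; others in the source may bear on it.

Compound 1 `CN(C)CCCNc1nc(NCc2ccco2)c2ccccc2n1` and compound 2 `Cc1cccc(N2CCN(CCCCNc3nc(NCc4ccco4)c4ccccc4n3)CC2)c1C` share one core; compound 3 `CN(C)CCNc1nc(NCc2ccco2)c2ccccc2n1` belongs to the same series, and in a functional assay on HT-29 cells (Homo sapiens) for cytotoxicity, read by MTT assay, with a stated time of 2 days (on this read-out higher numbers stand for weaker inhibition and lower numbers for stronger inhibition), compound 3 gives "not determined" (no result reported). In this assay compound 1 gives 4450 nM, while compound 2 gives 860 nM, the lowest of the two numbers, with compound 1 standing higher by an amount beyond the scatter. Compound 4 `Cc1cccc(N2CCN(CCCCNc3nc(NCc4ccco4)c4cc(F)ccc4n3)CC2)c1C` is the next member to be tested in this assay. It differs from compound 2 in one place on the core: fluoro in place of hydrogen on an aromatic carbon. Within the data shown here, no measured pair shows what this change does. In this assay the step is expected to be small, within the scatter and of no settled direction, amounting to a 1.1-fold lower number from compound 2 to compound 4 (0.03 log units; within the scatter). Compound 4 is therefore estimated at 800 nM, with a range from 350 nM to 2000 nM.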

Compound 4, half-maximal inhibitory concentration: 1830 nM
Beside the measured number, compound 4's estimate is 2.3-fold (0.36 log units) below it; low and high end bracket the measured number.
By their numbers in this assay, from the lowest: compound 2; then compound 4; then compound 1.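

In this assay, fluoro in place of hydrogen on this aromatic carbon of the core, meta to a fused ring and para to a fused ring, gives weaker inhibition, with a 2.1-fold higher number from compound 2 to compound 4 (0.33 log units; beyond the scatter) as a modest step beyond the scatter. Among these compounds, this is the first measured one-place step, and it shows that this carbon is not indifferent to substitution. Nothing shown bears on the reason for the step.

From the compounds shown here alone, whether chloro, methoxy or an amine on the same carbon would shift the number in the same direction remains open. So does whether fluoro there would act alike with the side chain of compound 1.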